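The source may report more compounds than this note shows. Statements on the series, on what has been measured and on what is new or still open speak of the compounds shown alone.

In a functional assay on HOP-92 cells (Homo sapiens) for inhibition, read by sulforhodamine B assay, with a stated time of 48 h (a higher number here means a weaker inhibitor of growth, a lower number a stronger inhibitor of growth), compound 2 `COc1cc(-c2nn(-c3cccc(NC(=O)c4cccc(C(F)(F)F)c4)c3)cc2-c2ccncc2)ccc1Cl` gives 3120 nM, the highest of the three numbers, yet within the scatter of compound 1 `O=C(Nc1cccc(-n2cc(-c3ccncc3)c(-c3ccc(Cl)c(O)c3)n2)c1)Nc1cccc(C(F)(F)F)c1` at 2230 nM and of compound 3 `O=C(Nc1cccc(-n2cc(-c3ccncc3)c(-c3ccc(Cl)c(O)c3)n2)c1)Nc1cc(C(F)(F)F)cc(C(F)(F)F)c1` at 1750 nM. Compound 4 `COc1cc(-c2nn(-c3cccc(NC(=O)Nc4ccc(Cl)c(C(F)(F)F)c4)c3)cc2-c2ccncc2)ccc1Cl` differs from compound 2 by (4-chloro-3-(trifluoromethyl)phenyl)amino in place of 3-(trifluoromethyl)phenyl on a carbonyl carbon. Within the data shown here, the one single-point step measured, a 1.3-fold lower number from compound 1 to compound 3 (0.11 log units; within the scatter), stays within the scatter. Among the measured compounds shown here, compound 1 and compound 2 differ in two places, so their values show only that the two changes taken together stay within the scatter. For the measured compounds named here, no measured step bears directly on the chlorine of the entering group. Compound 4 is therefore expected at 2000 nM, with a range of 900 nM to 4500 nM. The expected step is a 1.6-fold lower number from compound 2 to compound 4 (0.19 log units; within the scatter), not beyond the scatter.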

Compound 4, concentration for total growth inhibition: 1480 nM
The estimate for compound 4 lay 1.4-fold (0.13 log units) above the measured number, and the stated range covers the measured number.
By their numbers in this assay, from the lowest: compounds 4, 3, 1 and 2 (each within the scatter of the next, the first and the last beyond it).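

In this assay, the replacement at this carbonyl carbon gives a 2.1-fold lower number from compound 2 to compound 4 (0.32 log units; beyond the scatter) and is the first step shown to pass the scatter, though only modestly, whereas the earlier single-place step, a 1.3-fold lower number from compound 1 to compound 3 (0.11 log units; within the scatter), did not. The entering group brings the amino and the chlorine together, so the step belongs to the pair and not to either part alone. Nothing measured here accounts for the step.

The compounds shown leave open how the step divides between the amino and the chlorine. Also open, on these data alone, is whether a fluorine or a nitrile in place of that chlorine would keep it.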